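Propargyloxy in place of propoxy on an inactive pair

The source may hold more compounds than are shown below. What is called first, only, known or untested is meant among the compounds shown, and "the series" means these compounds.

Compound 1 `CCCOc1ccc(-c2cn3c(=O)n(-c4ccccc4)nc3c(N)n2)cc1` reaches in a functional assay on cells for antagonist activity at adenosine receptor A2b (Homo sapiens), read by cAMP accumulation, with a stated time of 10 min (a lower number here means a stronger inhibitor, a higher number a weaker inhibitor), only a limit, > 30000 nM, so its standing is known only as outside the measured range. Compound 2 `O=c1[nH]c(-c2ccc(O)cc2)cn2c(=O)n(-c3ccccc3)nc12` likewise gives only a limit in this assay, > 30000 nM. The line the limit of > 30000 nM in this assay, at which 2 of the 2 values shown sit, marks where every value of this series sits. Compound 3 `C#CCOc1ccc(-c2cn3c(=O)n(-c4ccccc4)nc3c(N)n2)cc1` carries the change (ethynyl in place of ethyl on a saturated chain carbon bound to an oxygen on an aromatic ring), ethynyl in place of ethyl on a saturated chain carbon bound to an oxygen on an aromatic ring. Going by the values given here, no measured step speaks to this change; the expected step, a number no higher from compound 1 to compound 3 (the limit leaves the size open), is none beyond the scatter. Compound 3 is accordingly estimated at 30000 nM, within 10000 nM to 100000 nM, most probably again reported only as a limit.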

Compound 3, half-maximal inhibitory concentration: > 30000 nM
Compound 3: no number, only a limit; the forecaster's own chance of this, stated with the estimate: 85%; the middle value lies on the limit itself.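

No step can be read between compound 1 and compound 3, since both values are only limits: the limit of > 30000 nM in this assay, at which 3 of the 3 values shown sit. The compounds shown leave open how far each lies from that limit in this assay and which change would give a measurable value.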